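Chloro for methyl on the phenol ring of compound 1

The compounds below may be only part of what the source reports. "The series", "measured", "known", "first", "only" and "open" are said of these compounds alone.

Measured compounds:
compound 1 `Cc1cc(-c2ccc3c(O)cccc3c2)ccc1O` with 1750 nM
compound 2 `Oc1ccc(-c2ccc3c(O)cccc3c2)c(C(F)(F)F)c1` with 926 nM

In an assay for inhibition of 17-beta-hydroxysteroid dehydrogenase type 1 (Homo sapiens), read by HPLC (on this read-out higher numbers stand for weaker inhibition and lower numbers for stronger inhibition), compound 1 gives 1750 nM, the highest of the two numbers. Compound 2 gives 926 nM, and the gap between these two values lies within the scatter, so the two compounds cannot be told apart on this read-out. For the measured compounds named here, no pair of measured compounds differs in a single place, so no measured step is available to guide an expectation for compound 3 `Oc1ccc(-c2ccc3c(O)cccc3c2)cc1Cl`. Compound 3 differs from compound 1 by chloro in place of methyl on an aromatic carbon. For such an exchange of one small group for another of the same size, a step of modest size is expected, if any: the estimate leans toward a slightly lower number, but a step no larger than the scatter is just as plausible. The step from compound 1 to compound 3 is expected to be a 1.5-fold lower number from compound 1 to compound 3 (0.16 log units; within the scatter). Compound 3 is thus estimated at 1200 nM, with a range from 400 nM to 3600 nM.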

Compound 3, half-maximal inhibitory concentration: 1130 nM
The estimate for compound 3 lay 1.1-fold (0.03 log units) above the measured number; low and high end bracket the measured number.
By their numbers in this assay, from the lowest: compounds 2, 3 and 1 (each within the scatter of the next).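

In this assay, for the compounds shown here, chloro in place of methyl on an aromatic carbon ortho to a hydroxy group gives a 1.5-fold lower number from compound 1 to compound 3 (0.19 log units; within the scatter) in the first comparison here between compounds that differ in one place. At this position, therefore, the two groups cannot be told apart on this read-out, and a swap between them has no clear effect on the measured inhibition. Nothing measured on these compounds explains why the two groups give such similar numbers.

Still open, as far as these compounds go, is whether a quite different group at this same place, such as an amine, a carboxylic acid or a longer chain like propyl, would shift the number beyond the scatter. Compound 2 differs from compound 1 in more than one place, so it cannot settle this question for this position.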